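This account rests on a few compounds, and the source may have more. Where it says the series, first, only, none or still open, it means among the compounds named here.

Three measured compounds set the scene. Compound 1 `NS(=O)(=O)c1ccc(Nc2ncc(F)c(Nc3nc4ccccc4s3)n2)cc1` is measured in a functional assay on MDA-MB-231 cells (Homo sapiens) for antiproliferative activity, read by MTT assay, with a stated time of 48 h (on this read-out lower numbers stand for stronger inhibition and higher numbers for weaker inhibition), where compound 1 gives 22600 nM. Compound 2 `Cc1cnc(Nc2ccc(S(N)(=O)=O)cc2)nc1Nc1nc2ccccc2s1` differs from compound 1 in one place, (methyl in place of fluoro on an aromatic carbon), and in this assay compound 2 gives 16800 nM. That single change produces a 1.3-fold lower number from compound 1 to compound 2 (0.13 log units; within the scatter). Compound 3 `NS(=O)(=O)c1ccc(Nc2nccc(Nc3nc4ccc(F)cc4s3)n2)cc1` has the same atoms as compound 1 joined differently; the difference between the two cores is not broken down here. In this assay compound 3 gives 1800 nM, which stands as the lowest of the three numbers, beyond the scatter from both compound 1 and compound 2.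

Compound 4 `Cc1ccc2nc(Nc3ccnc(Nc4ccc(S(N)(=O)=O)cc4)n3)sc2c1` is not yet measured. It differs from compound 3 by methyl in place of fluoro on an aromatic carbon. Among the measured compounds shown here, this is the same kind of change as the one from compound 1 to compound 2, not the same: there the place was on a six-membered aromatic ring with 2 nitrogen, ortho to a large group, two atoms from the ring nitrogen and para to a large group, whereas here it is on a six-membered aromatic ring of carbon only, part of a fused system of two rings, meta to a fused ring and para to a fused ring. For the measured compounds named here, the one measured example of this kind of change, a 1.3-fold lower number from compound 1 to compound 2 (0.13 log units; within the scatter), stayed within the scatter, so compound 4 is expected to show a comparably small step, a 1.2-fold lower number from compound 3 to compound 4 (0.08 log units; within the scatter), resting on compound 3 at 1800 nM. Compound 4 is therefore estimated at 1500 nM, likely between 500 nM and 4500 nM.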

Compound 4, half-maximal inhibitory concentration: 3870 nM
Compound 4: middle estimate off by 2.6-fold (0.41 log units), on the low side, within the range that was stated.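

In this assay, methyl in place of fluoro on an aromatic carbon of the carbon-only ring gave a 2.2-fold higher number from compound 3 to compound 4 (0.33 log units; beyond the scatter), a modest weakening where the earlier exchange had shown no step beyond the scatter. The exchange therefore did not carry over unchanged from one core to the other: the same change on two cores in this assay, a 1.3-fold lower number (0.13 log units; within the scatter) from compound 1 to compound 2 and a 2.2-fold higher number (0.33 log units; beyond the scatter) from compound 3 to compound 4, 2.9-fold (0.46 log units) apart, beyond the scatter of two such steps. This shows that, in these two pairs, the earlier step cannot be used to predict the later one, but it does not show what sets them apart, as the core and the place on the ring differ together and each is represented by a single pair.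

The compounds shown leave open how other groups at this place on the carbon-only ring, such as chloro, methoxy or an amine, would compare with fluoro and methyl, and how a compound carrying only hydrogen there would stand against compound 3 and compound 4. They also leave open whether moving the methyl or the fluoro to another carbon of that ring, with the rest of the structure kept, would give a step of similar size.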